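This account rests on a few compounds, and the source may have more. Where it says the series, first, only, none or still open, it means among the compounds named here.

In a functional assay on BT-549 cells (Homo sapiens) for inhibition, read by sulforhodamine B assay, with a stated time of 48 h, tested at 1 uM (on this read-out higher numbers stand for a weaker effect at the one concentration tested and lower numbers for a stronger effect), compound 1 `O=C(Nc1cccc(-n2cc(-c3ccncc3)c(-c3cc(O)cc(Cl)c3)n2)c1)Nc1ccc(Cl)c(C(F)(F)F)c1` gives 90%, compound 2 `COc1cc(Cl)cc(-c2nn(-c3cccc(NC(=O)Nc4ccc(Cl)c(C(F)(F)F)c4)c3)cc2-c2ccncc2)c1` gives 92%, and compound 3 `COc1cc(Cl)cc(-c2nn(-c3cccc(NC(=O)Nc4cc(C(F)(F)F)cc(C(F)(F)F)c4)c3)cc2-c2ccncc2)c1` gives 54%. The only step so far among these, a number 2 percentage points higher from compound 1 to compound 2 (within the scatter), changes nothing that can be told apart from the scatter. Compound 3 therefore stands lowest of the three, its gap to compound 1 and to compound 2 each lying beyond the scatter, so it shows the strongest effect seen here. Compound 4 `COc1cc(Cl)cc(-c2nn(-c3cccc(NC(=O)Nc4cccc(C(F)(F)F)c4)c3)cc2-c2ccncc2)c1` differs from compound 3 in one place: hydrogen in place of trifluoromethyl on an aromatic carbon. For the measured compounds named here, no measured step touches this position. Going by the values given here, compounds 1 and 2, which carry a chlorine and a single trifluoromethyl on that ring rather than two trifluoromethyls, both sit high, and that is the only guide available. The loss of one trifluoromethyl is thus expected to weaken the effect, and compound 4 is expected to give 80%, within 60% to 98%. The expected step, a number 26 percentage points higher from compound 3 to compound 4 (beyond the scatter), is upward and beyond the scatter, though with real uncertainty.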

Compound 4, a percentage reported as activity, at one concentration (the size of the read-out at that concentration, not a potency): 93%
For compound 4 the middle estimate is 13 percentage points below the measured one, within the range that was stated.
By their numbers in this assay, from the lowest: compound 3; then compounds 1, 2 and 4 (each within the scatter of the next).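

In this assay, for the compounds shown here, the swap to hydrogen at this carbon, meta to a trifluoromethyl group, gives a number 39 percentage points higher from compound 3 to compound 4 (beyond the scatter) and is the first measured change here at this position, so this second trifluoromethyl makes a large difference to the effect at the one concentration tested. Losing a group from this ring does not always matter, since hydrogen in place of chloro gives a number 1 percentage points higher from compound 2 to compound 4 (within the scatter) and leaves the read-out indistinguishable. Nothing available here explains why the two changes differ.

Only trifluoromethyl and hydrogen appear at this carbon in the compounds shown, so it remains open whether another group there, such as a nitrile, an amine or a carboxylic acid, could match trifluoromethyl. On these data alone, it also remains open whether the large step would recur with the hydroxyl of compound 1 in place of the methoxy group.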